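The source may hold more compounds than are shown below. What is called first, only, known or untested is meant among the compounds shown, and "the series" means these compounds.

Compound 1, `O=C1c2ccccc2N(COCc2ccccc2)S(=O)(=O)N1Cc1ccccc1`, stands in a functional assay on HEL cells (Homo sapiens) (a lower number here means that less compound is tolerated, a higher number that more compound is tolerated), at > 50 ug/mL, which is a limit of the assay and not a number. Compound 2, `O=C1NS(=O)(=O)N(COCc2ccccc2)c2ccccc21`, stands in this assay at > 50 ug/mL, again a limit. The step that the two limits leave unreadable from compound 1 to compound 2 therefore cannot be sized. Compound 3, `C#CCOCN1c2ccccc2C(=O)N(Cc2ccccc2)S1(=O)=O`, differs from compound 1 by ethynyl in place of phenyl on a saturated chain carbon bound to an oxygen on a saturated carbon. Within the data shown here, no measured step bears on this change; the only evidence on record is the limit of > 50 ug/mL in this assay, at which 2 of the 2 values shown sit. For compound 3 the expected step that the limit leaves unreadable from compound 1 to compound 3 is none beyond the scatter. Compound 3 is accordingly estimated at 60 ug/mL, expected to lie within 30 ug/mL to 150 ug/mL.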

Compound 3, half-maximal cytotoxic concentration: > 50 ug/mL
Compound 3: no number, only a limit; the forecaster's own chance of this, stated with the estimate: 75%; the middle value is on the limit's open side.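

In this assay, among these compounds, compound 3 gives > 50 ug/mL as a limit and not a number, so no step from compound 1 to compound 3 can be read. The compounds shown leave open whether ethynyl in place of phenyl changes the read-out at all.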